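The source may report more compounds than this note shows. Statements on the series, on what has been measured and on what is new or still open speak of the compounds shown alone.

Compound 1 `COc1ccccc1/C=C(\C(=O)c1ccc(Br)cc1)S(=O)(=O)c1ccc(C)cc1` and compound 2 `COc1ccccc1/C=C(\C(=O)c1ccc(Br)cc1)S(=O)(=O)Cc1ccc(F)cc1` share a common core and differ only on the sulfonyl sulfur. In a functional assay on DU-145 cells (Homo sapiens) for inhibition, read by trypan blue exclusion, with a stated time of 96 h (a lower number here means a stronger inhibitor of growth, a higher number a weaker inhibitor of growth), compound 1 gives 1000 nM, and compound 2 gives 25000 nM. The step of a 25-fold higher number from compound 1 to compound 2 (1.40 log units; beyond the scatter) is the only measured one, and it places compound 2 as the higher of the two numbers, so compound 2 is the weaker growth inhibitor of the pair.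

Compound 3 `O=C(/C(=C\c1ccc(Br)cc1)S(=O)(=O)Cc1ccc(F)cc1)c1ccc(Br)cc1` is not yet measured. It is compound 2 with 4-bromophenyl in place of 2-methoxyphenyl on a double-bonded chain carbon bound to a double-bonded chain carbon. Among the compounds with values here, this change lies on the double-bonded chain carbon, not on the sulfonyl sulfur, so the measured step from compound 1 to compound 2 does not bear on it directly: no measured pair shows what an exchange at this place does in this assay. With no guide either way, the author expects a step for compound 3 of about no change at the digits printed from compound 2 to compound 3 (within the scatter), which means no change beyond the scatter. Compound 3 is therefore estimated at 25000 nM in this assay, with a range from 8000 nM to 80000 nM.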

Compound 3, concentration for 50% growth inhibition: 25000 nM
The estimate for compound 3 equals the measured number at the digits printed; low and high end bracket the measured number.
By their numbers in this assay, from the lowest: compound 1; then compounds 2 and 3 (each within the scatter of the next).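

In this assay, within the data shown here, 4-bromophenyl in place of 2-methoxyphenyl on a double-bonded chain carbon bound to a double-bonded chain carbon gives no change at the digits printed from compound 2 to compound 3 (within the scatter), so this position now has one measured exchange, which the earlier compounds did not provide. The group that leaves counts one hydrogen-bond acceptor and the group that enters none, yet with 4-fluorobenzyl held on the sulfonyl sulfur, this pair shows no difference beyond the scatter. Nothing measured here speaks to the reason for this outcome.

The compounds shown leave open whether the same exchange would read alike with 4-methylphenyl on the sulfonyl sulfur, the group carried by compound 1 at 1000 nM, since this single pair rests on the weaker 4-fluorobenzyl background. They also leave open what an amine or a carboxylic acid on the aromatic ring at this double-bonded chain carbon would do in this assay, so a single exchange cannot yet describe how this position responds more widely.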